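The compounds below may be only part of what the source reports. "The series", "measured", "known", "first", "only" and "open" are said of these compounds alone.

Compound 2 `O=C(Nc1cccc(Cl)c1)c1ccc(/N=N\c2c[nH]c3ccccc23)cc1` stands, in a functional assay on HCT-116 cells (Homo sapiens) for inhibition, read by MTT assay, with a stated time of 72 h (on this read-out lower numbers stand for stronger inhibition and higher numbers for weaker inhibition), at 80000 nM, the lowest of the two numbers recorded. Going by the values given here, its only neighbour is compound 1 `Cc1cccc(NC(=O)c2ccc(/N=N\c3c[nH]c4ccccc34)cc2)c1C`, which in this assay gives 272000 nM; the one measured step, a 3.4-fold lower number from compound 1 to compound 2 (0.53 log units; beyond the scatter), lies beyond the scatter and is therefore the only guide to how a change on the amide-type nitrogen moves the read-out. Compound 3 `Cc1ccccc1NC(=O)c1ccc(/N=N\c2c[nH]c3ccccc23)cc1` is not yet measured and differs from compound 2 by 2-methylphenyl in place of 3-chlorophenyl on an amide-type nitrogen. The step from compound 1 to compound 2 bears on this change only loosely, since compound 3 returns to a methyl-bearing phenyl of the kind seen in compound 1 but not to the same one. A step of modest size in the direction of compound 1 is expected, with a higher number than compound 2 rather than a lower one. Compound 3 is therefore estimated at 180000 nM, within a range of 60000 nM to 500000 nM, a step of a 2.3-fold higher number from compound 2 to compound 3 (0.35 log units; beyond the scatter).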

Compound 3, half-maximal inhibitory concentration: 509000 nM
Compound 3: the middle estimate sits 2.8-fold (0.45 log units) below what was measured, outside the stated range (above it).
By their numbers in this assay, from the lowest: compound 2; then compounds 1 and 3 (each within the scatter of the next).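

In this assay, replacing the 3-chlorophenyl on the amide-type nitrogen with 2-methylphenyl gives a 6.4-fold higher number from compound 2 to compound 3 (0.80 log units; beyond the scatter), which shows that a single methyl-bearing phenyl does not hold the read-out near that of compound 2. Taking one methyl away from the 2,3-dimethylphenyl gives a 1.9-fold higher number from compound 1 to compound 3 (0.27 log units; within the scatter), so this methyl makes no difference that can be read here, and among these three compounds only the 3-chlorophenyl stands apart from the other two. No measurement available here explains this separation.

The compounds shown leave open whether the chlorine itself or its place on the phenyl carries the difference, since chlorine appears only once. They also leave open how a methoxy group or an amine on that phenyl would read in this assay.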